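Pyrazinyl to methoxypyridinyl on a shared triazolopyridazine-free core

The source may report more compounds than this note shows. Statements on the series, on what has been measured and on what is new or still open speak of the compounds shown alone.

Measured compounds:
- compound 1, `COc1ccc(OC)c(Sc2ccc3nnc(-c4ccccc4)n3n2)c1`: 1380 nM
- compound 2, `COc1ccc(OC)c(Sc2ccc3nnc(-c4ccncc4)n3n2)c1`: "not determined" (no result reported)
- compound 3, `COc1ccc(OC)c(Sc2ccc3nnc(-c4cnccn4)n3n2)c1`: "not determined" (no result reported)

Compound 3 stands without a number in an assay on HEK293 cells for inhibition of Leucine-rich repeat serine/threonine-protein kinase 2 (Homo sapiens), read by ELISA, with a stated time of 90 min; a lower number here means a stronger inhibitor, a higher number a weaker inhibitor; compound 2 likewise has no result there. Only compound 1 carries a value in this assay, 1380 nM. Compound 4, `COc1cncc(-c2nnc3ccc(Sc4cc(OC)ccc4OC)nn23)c1`, differs from compound 3 by one change: 5-methoxypyridin-3-yl in place of pyrazin-2-yl on an aromatic carbon. For the measured compounds named here, no step between measured compounds is available, so the size of this move in this assay cannot be anchored; the single number for compound 1 suggests that aryl variation at this site stays in the micromolar range, and no shift beyond the scatter is expected in either direction. Compound 4 is estimated at 1000 nM, with a likely range from 200 nM to 5000 nM.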

Compound 4, half-maximal inhibitory concentration: 440 nM
For compound 4 the middle estimate is 2.3-fold (0.36 log units) above the measured one; the measured number falls inside the stated range.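

In this assay, this place on the five-membered ring gains its first readable step: 5-methoxypyridin-3-yl in place of phenyl gives a 3.1-fold lower number from compound 1 to compound 4 (0.50 log units; beyond the scatter), so exchanging the aromatic ring here can move the number beyond the scatter. Steps involving compound 2 or compound 3 cannot be read, as neither has a value. Nothing at hand explains the step.

Whether the step follows the methoxy group or the ring nitrogen remains open, as the compounds shown never change one without the other. Also open, on these data alone, is how an amine or a carboxylic acid on this ring would read.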